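This account rests on a few compounds, and the source may have more. Where it says the series, first, only, none or still open, it means among the compounds named here.

Values so far in an ADME assay on microsomes from liver (Mus musculus) for metabolic stability, read by LC-MS, with a stated time of 1 h, tested at 5 uM; a lower number here means that less of the compound is left, a higher number that more of the compound is left:
- Compound 1 (`Cc1ccc(C)c(N2CCN(C(=O)c3oc(C)nc3-c3ccccc3)CC2)c1`) gives 1.4%
- Compound 2 (`Cc1cc(C)cc(N2CCN(C(=O)c3oc(C)nc3-c3ccccc3)CC2)c1`) gives 12%
- Compound 3 (`COc1cc(OC)cc(N2CCN(C(=O)c3oc(C)nc3-c3ccccc3)CC2)c1`) gives 0.7%

Compound 3 stands at the low end of these numbers together with compound 1, and the change between those two is a number 0.7 percentage points lower from compound 1 to compound 3 (within the scatter). The other measured step that reaches it is larger: a number 11.3 percentage points lower from compound 2 to compound 3 (beyond the scatter).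

The next compound, compound 4 (`Cc1nc(-c2ccccc2)c(C(=O)N2CCN(c3cccc(C#N)c3)CC2)o1`), differs from compound 3 in one place: 3-cyanophenyl in place of 3,5-dimethoxyphenyl on an amine nitrogen in a ring. Within the data shown here, the three measured steps all exchange the group on this amine nitrogen in a ring, so they give a sense of scale, but none of the measured compounds carries a nitrile. Among the measured compounds shown here, only one exchange lifts the number clear of the low end, a number 10.6 percentage points higher from compound 1 to compound 2 (beyond the scatter), and that step is modest. The other two measured compounds remain close together, so a large rise would go beyond anything seen here. With so little room below compound 3 (0.7%), any clear movement is expected to be upward.

The expected step is small and upward: a number 7.3 percentage points higher from compound 3 to compound 4 (within the scatter). For compound 4 the estimated value is 8%, with an expected range from 1% to 25%.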

Compound 4, percent of the compound remaining: 1.6%
Estimate against measurement, compound 4: 6.4 percentage points above, within the range that was stated.
By their numbers in this assay, from the lowest: compounds 3, 1 and 4 (each within the scatter of the next); then compound 2.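

Among these compounds, with 3-cyanophenyl on the amine nitrogen in a ring, the position now carries a nitrile for the first time, and in this assay compound 4 stays with the two lowest compounds (a number 0.9 percentage points higher from compound 3 to compound 4 (within the scatter)) and (a number 0.2 percentage points higher from compound 1 to compound 4 (within the scatter)). The exchange of 3,5-dimethoxyphenyl for this group, with its smaller heavy-atom count, therefore leaves the read-out within the scatter, and three different groups at this position now give numbers that cannot be told apart. Compound 2 alone remains apart from the others, and the new comparison shows this again (a number 10.4 percentage points lower from compound 2 to compound 4 (beyond the scatter)), while nothing available explains why 3,5-dimethylphenyl separates from the other three groups.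

Going by these compounds, it stays open whether a 3,5-dichlorophenyl or a 3-trifluoromethylphenyl group on this amine nitrogen would stand with compound 2 (12%) or with the three low compounds. Also open, on these data alone, is whether a single methyl, as in 3-methylphenyl, would be enough to keep the number clear of the low end.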